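Swapping Diethylamino for Ethoxy in a Cytotoxicity Series

The source may hold more compounds than are shown below. What is called first, only, known or untested is meant among the compounds shown, and "the series" means these compounds.

Measured so far:
Compound 1, `CCOc1ccc2cc(C(=O)NCCO)c(=O)oc2c1`, gives > 100000 nM in a functional assay on HCT-116 cells (Homo sapiens) for cytotoxicity, read by MTT assay, with a stated time of 72 h; on this read-out higher numbers stand for weaker inhibition and lower numbers for stronger inhibition.
Compound 2, `CCN(CC)c1ccc2cc(C(=O)NN)c(=O)oc2c1`, gives 3360 nM in this assay.

The value of compound 1 is a limit of this assay, not a measured number. Compound 2 therefore stands as the only real number shown; the other result is only a limit, (the limit of > 100000 nM in this assay, at which 1 of the 2 values shown sits). Compound 3, `CCOc1ccc2cc(C(=O)NN)c(=O)oc2c1`, shares the hydrazide of compound 2 and differs from it by ethoxy in place of diethylamino on an aromatic carbon. For the measured compounds named here, no step between two measured compounds covers this exchange, since compound 1 differs from compound 3 at the amide as well. Compound 1, carrying the same ethoxy group, shows only a limit, so the new group alone cannot be followed in the data. The step in this assay is expected to be moderate and toward weaker inhibition, with the outcome uncertain enough that a limit could appear again. Compound 3 is estimated at 15000 nM, between 3000 nM and 100000 nM, an expected step of a 4.5-fold higher number from compound 2 to compound 3 (0.65 log units; beyond the scatter).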

Compound 3, half-maximal inhibitory concentration: > 100000 nM
Compound 3 was reported as a limit; the forecaster's own chance of this, stated with the estimate: 25%; at least 6.6-fold (0.82 log units) between middle value and limit.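

In this assay, exchanging diethylamino for ethoxy on the aromatic carbon, with the hydrazide left unchanged, gives an at least 29-fold higher number from compound 2 to compound 3 (1.47 log units; beyond the scatter). Compound 3 gives > 100000 nM, which is a limit of the assay and not a number. Compound 1 differed from compound 2 in two places, so it could not isolate the effect of this aromatic carbon's substituent; this pair shows that the hydrazide alone does not keep a measurable value once ethoxy replaces diethylamino, and the printed size of the step is only a minimum, as the result falls at the limit again: the limit of > 100000 nM in this assay, at which 2 of the 3 values shown sit.

From the compounds shown here alone, the step between compound 1 and compound 3 cannot be read since both results are limits, so the effect of amino in place of 2-hydroxyethyl on the amide-type nitrogen remains unknown with ethoxy in place. Also open, going by these compounds, is whether diethylamino itself is needed, or whether another amine such as dimethylamino or morpholine, or a longer ether chain such as butoxy, on the same aromatic carbon would give a measurable value alongside the hydrazide.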